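Changing the acid-bearing ring of a bile acid receptor agonist

This account rests on a few compounds, and the source may have more. Where it says the series, first, only, none or still open, it means among the compounds named here.

Three compounds sharing one core differ only in the acid-bearing ring attached to a saturated ring carbon. In an assay on HEK293T cells for agonist activity at Bile acid receptor (Homo sapiens), read by a luciferase reporter (a lower number here means that less compound is needed, a higher number that more compound is needed for the effect), compound 3 `Cc1cc(OCc2c(-c3c(Cl)cccc3Cl)noc2C2CC2)ccc1C1=NOC(c2ccc(C(=O)O)nc2)C1` gives 5 nM, the lowest of the two numbers reported. Its nearest neighbour, compound 2 `Cc1cc(OCc2c(-c3c(Cl)cccc3Cl)noc2C2CC2)ccc1C1=NOC(c2cc(C(=O)O)ccn2)C1`, gives 17 nM in this assay. For compound 1 `Cc1cc(OCc2c(-c3c(Cl)cccc3Cl)noc2C2CC2)ccc1C1=NOC(c2cccc(C(=O)O)c2)C1` this assay returns only a limit, < 30 nM, and not a number (the limit of < 30 nM in this assay, at which 1 of the 3 values shown sits). The steps from compound 1 therefore cannot be sized: a step that the limit leaves unreadable from compound 1 to compound 2 and a step that the limit leaves unreadable from compound 1 to compound 3. Within the data shown here, the one readable step is a 3.4-fold lower number from compound 2 to compound 3 (0.53 log units; beyond the scatter), which shows that rearranging the acid-bearing six-membered ring shifts the number by a modest amount.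

Compound 4 `CCn1nc(C(=O)O)cc1C1CC(c2ccc(OCc3c(-c4c(Cl)cccc4Cl)noc3C3CC3)cc2C)=NO1` is not yet measured. Relative to compound 3 it carries a group of 10 heavy atoms (6 carbon, 2 nitrogen, 2 oxygen; one five-membered aromatic ring with 2 hetero atoms) in place of a group of 9 heavy atoms (6 carbon, 1 nitrogen, 2 oxygen; one six-membered aromatic ring with 1 hetero atom), on a saturated ring carbon. Among the measured compounds shown here, no measured step exchanges a six-membered ring for a five-membered one at this position, so the readable step between compound 2 and compound 3 is the only guide, and it suggests changes of modest size. Compound 4 is therefore expected to remain close to compound 3, with a step of a 2.4-fold higher number from compound 3 to compound 4 (0.38 log units; beyond the scatter) in this assay. The estimate for compound 4 in this assay is 12 nM, within a range from 3 nM to 50 nM.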

Compound 4, half-maximal effective concentration: 23 nM
Compound 4: middle estimate off by 1.9-fold (0.28 log units), on the low side, and the stated range covers the measured number.
By their numbers in this assay, from the lowest: compound 3; then compounds 2 and 4 (each within the scatter of the next).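

In this assay, this position on the saturated ring carbon, next to the ring oxygen, accepts a five-membered aromatic ring with 2 hetero atoms, at a modest cost against the best six-membered ring shown: a 4.6-fold higher number from compound 3 to compound 4 (0.66 log units; beyond the scatter). Against the other pyridine acid the same kind of exchange shows no readable change, a 1.4-fold higher number from compound 2 to compound 4 (0.13 log units; within the scatter), so the choice of ring here does not separate five-membered from six-membered rings as such, and compound 3 is set apart from both compound 2 and compound 4 by steps beyond the scatter. The steps from compound 1, which carries the all-carbon ring, cannot be read, since compound 1 returns a limit and not a number: the limit of < 30 nM in this assay, at which 1 of the 4 values shown sits.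

Only one five-membered ring appears, so the compounds shown cannot tell whether the step to compound 4 follows from ring size or from the other atoms of the entering group, and a thiazole carrying the same acid would help to separate the two. Every compound shown also keeps a carboxylic acid on this ring, which leaves open how a tetrazole or an amide would read in its place.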